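A few compounds are considered here, and "the series" means these few. Any claim that something is new, unique, unknown or untested is made for them only; others in the source may bear on it.

Measured so far in a functional assay on V79 cells (Cricetulus griseus) for cytotoxicity, read by colony formation; a lower number here means a stronger inhibitor, a higher number a weaker inhibitor:
- compound 1 `CCNCC1CCN(c2c(F)cc3c(=O)c(C(=O)O)cn(C4CC4)c3c2F)C1` gives 11 ug/mL; 11 ug/mL; 11 ug/mL; 11 ug/mL (4 entries) in every repeat
- compound 2 `NCC1CCN(c2c(F)cc3c(=O)c(C(=O)O)cn(C4CC4)c3c2F)C1` gives 11 ug/mL in its single entry
- compound 3 `CC1(CN)CCN(c2c(F)cc3c(=O)c(C(=O)O)cn(C4CC4)c3c2F)C1` gives 8 ug/mL in its single entry

Compound 3 at 8 ug/mL sits in one narrow band with compound 1 and compound 2 and cannot be ranked against them. Compound 4 `CNCC1(C)CCN(c2c(F)cc3c(=O)c(C(=O)O)cn(C4CC4)c3c2F)C1` differs from compound 3 in one place: methyl in place of hydrogen on an amine nitrogen, so that aminomethyl becomes (methylamino)methyl.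

For the measured compounds named here, only one measured step is available, a 1.4-fold lower number from compound 2 to compound 3 (0.14 log units; within the scatter), and it places a methyl on a saturated ring carbon and not on an amine nitrogen. Going by the values given here, it therefore bears on the new change only indirectly, and no measured step covers methyl in place of hydrogen on an amine nitrogen. Compound 1 at 11 ug/mL; 11 ug/mL; 11 ug/mL; 11 ug/mL (4 entries) and compound 2 at 11 ug/mL show the same number. On this thin evidence, no shift beyond the scatter is expected in this assay and no direction can be assigned with confidence. The estimated step is a 1.1-fold higher number from compound 3 to compound 4 (0.05 log units; within the scatter) and counts as no real change. For compound 4 the expected value is 9 ug/mL with an estimated range from 5 ug/mL to 16 ug/mL in this read-out.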

Compound 4, half-maximal inhibitory concentration: 8 ug/mL
Estimate against measurement, compound 4: 1.1-fold (0.05 log units) above, within the range that was stated.
By their numbers in this assay, from the lowest: compounds 3, 4 and 2 (each within the scatter of the next).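

The amine nitrogen of the aminomethyl group now has a measured step of its own in this assay: methyl in place of hydrogen gives no change at the digits printed from compound 3 to compound 4 (within the scatter), where the earlier step placed a methyl only on a saturated ring carbon. Taken as one replacement, 3-methyl-3-((methylamino)methyl)pyrrolidin-1-yl in place of 3-(aminomethyl)pyrrolidin-1-yl gives a 1.4-fold lower number from compound 2 to compound 4 (0.14 log units; within the scatter), so the methyl on the ring carbon and the methyl on the amine nitrogen together still leave the read-out within the scatter across these compounds. No available measurement offers an explanation for this flat result.

Open, as far as these compounds go, is whether a dimethylamino group or an acetyl group on the same amine nitrogen would move the number in this assay beyond the scatter. The carboxylic acid and the cyclopropyl group stay the same throughout the compounds shown, so the response of this read-out to a methyl ester or an amide in place of that carboxylic acid, or to an ethyl group in place of that cyclopropyl group, remains open as well.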